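Ethyl to methoxy: expected shift in kinase inhibition

This account rests on a few compounds, and the source may have more. Where it says the series, first, only, none or still open, it means among the compounds named here.

Measured compounds:
compound 1 `O=C1c2ccccc2C(=O)N1CNc1ccc(F)cc1` gives 8740 nM in an assay on isolated protein for inhibition of ribosomal protein S6 kinase alpha-2 (Homo sapiens), read by fluorescence, with a stated time of 20 min; a lower number here means a stronger inhibitor, a higher number a weaker inhibitor
compound 2 `Cc1ccc(NCN2C(=O)c3ccccc3C2=O)cc1` gives 4300 nM
compound 3 `CCc1ccc(NCN2C(=O)c3ccccc3C2=O)cc1` gives 4310 nM

Among these three numbers compound 3 stands second highest; the step of a 1.0-fold higher number from compound 2 to compound 3 (0.00 log units; within the scatter) lies within the scatter, while a 2.0-fold lower number from compound 1 to compound 3 (0.31 log units; beyond the scatter) is modest but beyond it. Compound 4 `COc1ccc(NCN2C(=O)c3ccccc3C2=O)cc1` differs from compound 3 by methoxy in place of ethyl on an aromatic carbon. Among the compounds with values here, no measured step introduces methoxy. The steps at this position, a 2.0-fold lower number from compound 1 to compound 2 (0.31 log units; beyond the scatter) and a 2.0-fold lower number from compound 1 to compound 3 (0.31 log units; beyond the scatter), were both modest, and the exchange of methyl for ethyl moved nothing. The writer therefore expects no step beyond the scatter, a 1.0-fold higher number from compound 3 to compound 4 (0.02 log units; within the scatter). Compound 4 is estimated at 4500 nM, with a range from 2000 nM to 10000 nM.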

Compound 4, half-maximal inhibitory concentration: 470 nM
For compound 4 the middle estimate is 9.6-fold (0.98 log units) above the measured one, and the stated range ends above it.
By their numbers in this assay, from the lowest: compound 4; then compounds 2 and 3 (each within the scatter of the next); then compound 1.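

At this position, on an aromatic carbon para to a large group, methoxy stands apart from the earlier groups, with a 9.2-fold lower number from compound 3 to compound 4 (0.96 log units; beyond the scatter) and a 9.1-fold lower number from compound 2 to compound 4 (0.96 log units; beyond the scatter) and also a 19-fold lower number from compound 1 to compound 4 (1.27 log units; beyond the scatter) in this assay for this series. Ethyl and methoxy count the same number of heavy atoms and differ by one oxygen and one hydrogen-bond acceptor, so heavy-atom count alone does not track this step. No measurement at hand gives a reason for it.

On these data alone, whether ethoxy, hydroxyl or an amine at this position would behave like methoxy remains open, as does whether the step would hold with a different shared core.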